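Furan to thiophene exchange on a weakly active triaryl pyridine

The source may report more compounds than this note shows. Statements on the series, on what has been measured and on what is new or still open speak of the compounds shown alone.

Compound 1 `Oc1cccc(-c2cc(-c3ccco3)nc(-c3ccccc3Cl)c2)c1` is tested in an assay on isolated protein for inhibition of DNA topoisomerase 1 (Homo sapiens), with a stated time of 30 min, tested at 100 uM (a lower number here means a weaker effect, a higher number a stronger effect of the compound at the concentration tested), and gives 0%. Of the three measured compounds it shows the lowest number, yet all three lie within the scatter of one another. Compound 2 `Oc1ccc(-c2cc(-c3ccco3)nc(-c3ccccc3Cl)c2)cc1` gives 3.9% in this assay, and compound 3 `Oc1cccc(-c2cc(-c3cccc(Cl)c3)nc(-c3ccco3)c2)c1` gives 5.5%. The step of a number 3.9 percentage points higher from compound 1 to compound 2 (within the scatter) and the step of a number 5.5 percentage points higher from compound 1 to compound 3 (within the scatter) are both within the scatter, so neither a change of the hydroxyphenyl group nor a change of the chlorophenyl group on the shared core has moved the read-out beyond noise.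

Compound 4 `Oc1cccc(-c2cc(-c3cccs3)nc(-c3ccccc3Cl)c2)c1` has not yet been measured in this assay. It differs from compound 1 in this way: thiophen-2-yl in place of furan-2-yl on an aromatic carbon. Among the compounds with values here, no measured pair of the series changes the furan-2-yl group, so no step bears directly on this exchange; the two measured steps only show that changes elsewhere on the core stay within the scatter. Given that and the value 0% of compound 1, the step of a number 3 percentage points higher from compound 1 to compound 4 (within the scatter) is expected to stay within the scatter. The inhibition of compound 4 in this assay is therefore estimated at 3%, with a range from 0% to 14%.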

Compound 4, a percentage reported as inhibition, at one concentration (the size of the read-out at that concentration, not a potency): 2.7%
Estimate against measurement, compound 4: 0.3 percentage points above; low and high end bracket the measured number.
By their numbers in this assay, from the lowest: compounds 1, 4, 2 and 3 (each within the scatter of the next).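

The exchange of furan-2-yl for thiophen-2-yl on the aromatic carbon next to the ring nitrogen gives a number 2.7 percentage points higher from compound 1 to compound 4 (within the scatter) in this assay. Within the data shown here, this is the first reading at this position, and it joins the hydroxyphenyl and chlorophenyl changes in leaving the read-out within the scatter, so all four compounds on the shared core remain within the scatter of one another. Sulfur in place of oxygen in the five-membered aromatic ring, with the heavy-atom count unchanged, therefore does not separate compound 1 from compound 4 at the concentration tested, and no measurement is available that could explain this result.

The compounds shown leave open whether any other group at this position, such as an aminomethyl group, a carboxylic acid or a plain phenyl ring, would lift the read-out clear of the scatter. Also open is whether thiophen-2-yl combined with the 4-hydroxyphenyl or 3-chlorophenyl group would behave differently from each single change, and a read-out at one concentration gives no potency for any of these compounds.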